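The source may report more compounds than this note shows. Statements on the series, on what has been measured and on what is new or still open speak of the compounds shown alone.

Of the compounds shown here, three built on one shared core have been tested in a functional assay on SR cells (Homo sapiens) for inhibition, read by sulforhodamine B assay, with a stated time of 48 h; a higher number here means a weaker inhibitor of growth, a lower number a stronger inhibitor of growth. Compound 1 `COc1cc(-c2nn(-c3cccc(NC(=O)c4cccc(C(F)(F)F)c4)c3)cc2-c2ccncc2)ccc1Cl` gives 838 nM, compound 2 `COc1cc(-c2nn(-c3cccc(NC(=O)Nc4ccc(Cl)c(Cl)c4)c3)cc2-c2ccncc2)ccc1Cl` gives 932 nM, and compound 3 `COc1cc(-c2nn(-c3cccc(NC(=O)c4ccc(Cl)c(C(F)(F)F)c4)c3)cc2-c2ccncc2)ccc1Cl` gives 848 nM. Compound 3 stands second highest of these three numbers, with compound 1 nearest and compound 2 furthest, and both gaps lie within the scatter. Compound 4 `COc1cc(-c2nn(-c3cccc(NC(=O)Nc4ccc(Cl)c(C(F)(F)F)c4)c3)cc2-c2ccncc2)ccc1Cl` differs from compound 3 by (4-chloro-3-(trifluoromethyl)phenyl)amino in place of 4-chloro-3-(trifluoromethyl)phenyl on a carbonyl carbon. Going by the values given here, two measured steps bear on this change: a 1.1-fold higher number from compound 1 to compound 2 (0.05 log units; within the scatter), which also placed a (3,4-dichlorophenyl)amino group on the carbonyl carbon in place of an aryl group, and a 1.1-fold lower number from compound 2 to compound 3 (0.04 log units; within the scatter), which ran the other way. No step beyond the scatter is therefore expected in this assay. The estimate for compound 4 is 900 nM, with a range from 450 nM to 1800 nM. For compound 4 the expected step is a 1.1-fold higher number from compound 3 to compound 4 (0.03 log units; within the scatter).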

Compound 4, concentration for 50% growth inhibition: 884 nM
The estimate for compound 4 lay 1.0-fold (0.01 log units) above the measured number; the range from low to high includes it.
By their numbers in this assay, from the lowest: compounds 1, 3, 4 and 2 (each within the scatter of the next).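

In this assay, adding the amino link on the carbonyl carbon, now with the same 4-chloro-3-(trifluoromethyl)phenyl group on both sides, stays within the scatter (a 1.0-fold higher number from compound 3 to compound 4 (0.02 log units; within the scatter)). Trifluoromethyl in place of chloro on an aromatic carbon, seen alone for the first time, also stays within it (a 1.1-fold lower number from compound 2 to compound 4 (0.02 log units; within the scatter)), as does the change that adds both the amino link and the chloro (a 1.1-fold higher number from compound 1 to compound 4 (0.02 log units; within the scatter)). No measured evidence gives a reason for these results.

Going by these compounds, it remains open whether a different group on the carbonyl carbon, such as a longer alkyl chain or a phenyl ring carrying a carboxylic acid, would give a step beyond the scatter.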